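This account rests on a few compounds, and the source may have more. Where it says the series, first, only, none or still open, it means among the compounds named here.

Measured so far in a functional assay on HL-60 cells (Homo sapiens), read by calcium flux; a lower number here means that less compound is needed, a higher number that more compound is needed for the effect:
Compound 1 `Cc1cc(Cc2ccccc2)c(=O)n(CC(=O)Nc2ccc(Br)cc2)n1` gives > 50000 nM as a limit.
Compound 2 `Cc1cc(Cc2ccc(C(F)(F)F)cc2)c(=O)n(CC(=O)Nc2ccc(Br)cc2)n1` gives > 50000 nM as a limit.

Compound 2 therefore stands without a number, and the limit of > 50000 nM in this assay, at which 2 of the 2 values shown sit, describes the whole of the data. Among the measured compounds shown here, compound 3 `Cc1cc(Cc2cccnc2)c(=O)n(CC(=O)Nc2ccc(Br)cc2)n1` carries pyridin-3-yl in place of 4-(trifluoromethyl)phenyl on a saturated chain carbon bound to an aromatic carbon as its one change. For the measured compounds named here, the only measured step that bears on this is a step that the two limits leave unreadable from compound 1 to compound 2 and it touches the same aromatic ring, but its size cannot be read. It therefore offers no size to carry over, and no direction is expected from it in this assay. The estimated step of a number no higher from compound 2 to compound 3 (the limit leaves the size open) is correspondingly no more than a placeholder. Compound 3 is expected to remain near the limit, at an estimated 50000 nM within a range from 10000 nM to 100000 nM as the expected span.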

Compound 3, half-maximal effective concentration: > 50000 nM
Compound 3: a limit, no number (the forecaster's own chance of this, stated with the estimate: 85%); the middle value sits exactly at the limit.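

Among the compounds shown here, no step among compound 1, compound 2 and compound 3 can be read, as all three values are limits and not numbers: the limit of > 50000 nM in this assay, at which 3 of the 3 values shown sit.

The compounds shown leave open whether any group on this saturated chain carbon bound to an aromatic carbon gives a measurable value in this assay.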